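The compounds below may be only part of what the source reports. "The series", "measured", "known", "first", "only" and "open" are said of these compounds alone.

Measured in an ADME assay on liver for metabolic stability, with Liver microsome (Homo sapiens) as the target, read by LC-MS, using microsomes; a higher number here means faster removal of the compound, a lower number slower removal:
- compound 1 `O=C(NCc1cc(Cl)ccc1-n1cnnn1)[C@@H]1C[C@@H]2C[C@@H]2N1C(=O)[C@H](O)Cn1cccn1`: < 12 mL.min-1.g-1 (a limit)
- compound 2 `O=C(NCc1cc(Cl)ccc1-n1cnnn1)[C@@H]1C[C@H]2C[C@H]2N1C(=O)[C@H](O)c1ccccc1`: < 15 mL.min-1.g-1 (a limit)
- compound 3 `CC(C)(C)C[C@@H](O)C(=O)N1[C@H](C(=O)NCc2cc(Cl)ccc2-n2cnnn2)C[C@@H]2C[C@@H]21`: 40 mL.min-1.g-1

In this assay, for the measured compounds named here, compound 3 gives 40 mL.min-1.g-1, the only true number in the set. The other two readings are limits.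

Compound 4 `O=C(NCc1cc(Cl)ccc1-n1cnnn1)[C@@H]1C[C@@H]2C[C@@H]2N1C(=O)[C@H](O)c1ccccc1` is not yet measured. It differs from compound 3 by phenyl in place of neopentyl on a saturated chain carbon bound to a carbonyl carbon and an oxygen on a saturated carbon.

Going by the values given here, the one measured step, an at least 3.3-fold higher number from compound 1 to compound 3 (0.52 log units; beyond the scatter), brought in tert-butyl in place of 1H-pyrazol-1-yl at a chain carbon, so the end group can matter here. That step does not cover phenyl. Compound 2 also carries phenyl, although its core differs in stereochemistry. Its reading is a limit, < 15 mL.min-1.g-1.

On the strength of compound 2 and this step, a move towards slower removal is expected, with a limit rather than a number possible. The estimated change is a 2.5-fold lower number from compound 3 to compound 4 (0.40 log units; beyond the scatter). For compound 4 the expected value is 16 mL.min-1.g-1, with an estimated range of 8 mL.min-1.g-1 to 34 mL.min-1.g-1.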

Compound 4, intrinsic clearance in microsomes: < 16 mL.min-1.g-1
Compound 4 ended at the assay's limit; the forecaster's own chance of this, stated with the estimate: 50%; the middle value lies on the limit itself.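

In this assay, the saturated chain carbon bound to a carbonyl carbon and an oxygen on a saturated carbon now gives a second readable step: phenyl in place of neopentyl gives an at least 2.5-fold lower number from compound 3 to compound 4 (0.39 log units; beyond the scatter). For the compounds shown here, the earlier step showed only that the group at this position can matter, whereas this one shows that phenyl on the core of compound 3 also moves the reading towards slower removal, so neopentyl now stands against two different end groups that both end at a limit. The steps to compound 4 from compound 1 and from compound 2 cannot be read, since both ends of each are limits, and the phenyl pair therefore gives no size for any effect of the change in configuration: the fact that compounds 2 and 4 differ only in the configuration as drawn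

Still open, from the compounds shown here alone, is how far compound 4 actually lies from its limit, and with it whether phenyl and (1H-pyrazol-1-yl)methyl differ at all in this assay. A cyclohexyl group at this carbon would help to separate the aromatic ring of phenyl from its carbon count, and a pyridine ring would test a ring nitrogen in the same place.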